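Replacing a Five-Membered Aromatic Ring on the Chain Carbon

A few compounds are considered here, and "the series" means these few. Any claim that something is new, unique, unknown or untested is made for them only; others in the source may bear on it.

Compound 1 `CC(C)C(c1ncco1)c1ccc(-c2ccc3cccc(F)c3c2)[nH]c1=O`: 64 nM
Compound 2 `CCn1ncc2c(F)cc(-c3ccc(C(CC)(CC)c4nncn4C)c(=O)[nH]3)cc21`: 120 nM

Of the compounds shown here, two have been measured in a functional assay on CHO cells for antagonist activity at prostaglandin E2 receptor EP3 subtype (Homo sapiens), read by cAMP accumulation; a higher number here means a weaker inhibitor, a lower number a stronger inhibitor. Compound 1 gives 64 nM, the lower of the two numbers. Compound 2 gives 120 nM, and these two numbers sit within the usual scatter of each other, so no order between them can be claimed.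

Compound 3 `CC(C)C(c1ccc(-c2ccc3cccc(F)c3c2)[nH]c1=O)N1CCN/C1=N\C#N` has not yet been measured. It differs from compound 1 in one place: a group of 8 heavy atoms (4 carbon, 4 nitrogen; one five-membered non-aromatic ring with 2 hetero atoms) in place of a group of 5 heavy atoms (3 carbon, 1 nitrogen, 1 oxygen; one five-membered aromatic ring with 2 hetero atoms), on a saturated chain carbon bound to an aromatic carbon and a saturated chain carbon. Among the compounds with values here, no measured pair shows what this kind of change does, so the expectation rests on the shared core alone. The step from compound 1 to compound 3 is expected to be a 1.7-fold higher number from compound 1 to compound 3 (0.24 log units; within the scatter), most likely a small weakening that may not exceed the scatter. Compound 3 is therefore expected to give about 110 nM, within a range from 30 nM to 400 nM.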

Compound 3, half-maximal inhibitory concentration: 38 nM
For compound 3 the middle estimate is 2.9-fold (0.46 log units) above the measured one, and the stated range covers the measured number.
By their numbers in this assay, from the lowest: compounds 3, 1 and 2 (each within the scatter of the next, the first and the last beyond it).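

At this position, on a saturated chain carbon bound to an aromatic carbon and a saturated chain carbon, the five-membered aromatic ring is not essential. In this assay the swap to a larger, non-aromatic five-membered ring gives a 1.7-fold lower number from compound 1 to compound 3 (0.23 log units; within the scatter), so the change cannot be told apart from repeat-measurement noise even though the new group has more heavy atoms, a hydrogen-bond donor, and a double and a triple bond outside aromatic rings. Nothing available explains why such different groups give readings this close.

On these data alone, this single swap alters all those features at once, so the contribution of each remains unknown. As far as these compounds go, it also remains open whether much simpler groups on the same carbon, such as an amine or a carboxylic acid, would read similarly.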